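The source may report more compounds than this note shows. Statements on the series, on what has been measured and on what is new or still open speak of the compounds shown alone.

Of the compounds shown here, three sharing one core have been measured in a functional assay on A549 cells (Homo sapiens) for inhibition, read by CCK-8 assay, with a stated time of 72 h, tested at 1 uM; a higher number here means more inhibition of growth at the concentration tested, a lower number less inhibition of growth. Compound 1 `CN(C)C(=O)c1cc2cnc(Nc3ccc(NC(=O)C4(C(=O)Nc5cccc(Cl)c5)CC4)cc3)nc2n1C1CCCC1` gives 8.3%. Compound 2 `Cc1ccc(NC(=O)C2(C(=O)Nc3ccc(Nc4ncc5cc(C(=O)N(C)C)n(C6CCCC6)c5n4)cc3)CC2)cc1` gives 40.2%. Compound 3 `CN(C)C(=O)c1cc2cnc(Nc3ccc(NC(=O)C4(C(=O)Nc5cccc(C#N)c5)CC4)cc3)nc2n1C1CCCC1` gives 70.8%, the highest of the three, and its steps to both others lie beyond the scatter: a number 62.5 percentage points higher from compound 1 to compound 3 (beyond the scatter) and a number 30.6 percentage points higher from compound 2 to compound 3 (beyond the scatter). Compound 4 `CN(C)C(=O)c1cc2cnc(Nc3ccc(NC(=O)C4(C(=O)Nc5ccc(C(F)(F)F)cc5)CC4)cc3)nc2n1C1CCCC1` has not yet been measured. The change from compound 3 to compound 4 is 4-(trifluoromethyl)phenyl in place of 3-cyanophenyl on an amide-type nitrogen. The two measured steps that end at compound 3 bear on this change, since each of them also exchanged the group on the amide-type nitrogen for the 3-cyanophenyl; read the other way, leaving the 3-cyanophenyl, both were large falls, a number 62.5 percentage points higher from compound 1 to compound 3 (beyond the scatter) and a number 30.6 percentage points higher from compound 2 to compound 3 (beyond the scatter) reversed. Among the measured compounds shown here, no measured compound carries a 4-(trifluoromethyl)phenyl, so the size of the fall here is uncertain. A drop beyond the scatter is nonetheless expected, a number 40.8 percentage points lower from compound 3 to compound 4 (beyond the scatter). Compound 4 is therefore estimated at 30%, with a range from 5% to 60%.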

Compound 4, percent growth inhibition at one concentration: -25.3%
For compound 4 the middle estimate is 55.3 percentage points above the measured one; measured number below the stated range.
By their numbers in this assay, from the lowest: compound 4; then compound 1; then compound 2; then compound 3.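

In this assay, the group on the amide-type nitrogen can do more than weaken growth inhibition: compound 4 reads -25.3%, a number below zero, and the change from the 3-cyanophenyl gives a number 96.1 percentage points lower from compound 3 to compound 4 (beyond the scatter). The cleanest comparison is the pair that differs only in one group on an aromatic carbon, where trifluoromethyl in place of methyl gives a number 65.5 percentage points lower from compound 2 to compound 4 (beyond the scatter). Even against the 3-chlorophenyl, until now the lowest, the 4-(trifluoromethyl)phenyl gives a number 33.6 percentage points lower from compound 1 to compound 4 (beyond the scatter).

Nothing available explains why these numbers fall. Open too, on these data alone, is how a ring carrying an amine, a carboxylic acid or a methoxy group on the amide-type nitrogen would read, and whether the nitrile keeps its high number when it moves elsewhere on the ring.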